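Working notes: side-chain hydroxy removed, compound 3 to compound 4

The source may hold more compounds than are shown below. What is called first, only, known or untested is meant among the compounds shown, and "the series" means these compounds.

Measured so far in this assay:
compound 1 `CCC[C@@H](OC(C)=O)C1=C(Br)C(=C(Br)Br)OC1=O` — 3.5 ug/mL
compound 2 `CCC[C@@H](OC(C)=O)C1=C(Br)[C@@](CI)(OC)OC1=O` — 7.1 ug/mL
compound 3 `CCC[C@@H](O)C1=C(Br)C(=C(Br)Br)OC1=O` — 9.5 ug/mL

In a functional assay on KB cells (Homo sapiens) for cytotoxicity (on this read-out lower numbers stand for an effect already at smaller amounts and higher numbers for an effect only at larger amounts of compound), compound 3 has the highest of the three numbers. Its gap to compound 2 lies within the scatter, whereas the step of a 2.7-fold higher number from compound 1 to compound 3 (0.43 log units; beyond the scatter) lies beyond it. Compound 4 `CCCCC1=C(Br)C(=C(Br)Br)OC1=O` differs from compound 3 by hydrogen in place of hydroxy on a saturated chain carbon bound to a double-bonded ring carbon and a saturated chain carbon. Within the data shown here, the only measured step touching this carbon is the one from compound 1 to compound 3, which exchanged acetyl for hydrogen on the oxygen and moved the number modestly; no measured pair removes the oxygen itself, so the direction of the new step rests on that single comparison. A small step toward a lower number, near the scatter, is the working expectation, and compound 4 is estimated at 6.5 ug/mL (range 2.5 ug/mL to 18 ug/mL). That estimate means a step of a 1.5-fold lower number from compound 3 to compound 4 (0.16 log units; within the scatter), expected to be modest.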

Compound 4, concentration for half-maximal effect: > 20 ug/mL
Compound 4: no number, only a limit (the forecaster's own chance of this, stated with the estimate: 5%); middle value at least 3.0-fold (0.48 log units) away from the limit.
By their numbers in this assay, from the lowest: compound 1; then compounds 2 and 3 (each within the scatter of the next). At a limit, above all of these: compound 4.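

In this assay compound 4 stands at a limit of the assay, not at a number: the limit of > 20 ug/mL in this assay, at which 1 of the 4 values shown sits. With hydrogen in place of hydroxy the result is an at least 2.1-fold higher number from compound 3 to compound 4 (0.32 log units; beyond the scatter) and with hydrogen in place of acetoxy it is an at least 5.7-fold higher number from compound 1 to compound 4 (0.75 log units; beyond the scatter) on the same saturated chain carbon. Among compound 1, compound 3 and compound 4, an oxygen on this carbon, as hydroxy or as acetoxy, therefore goes with the lower numbers, which the acetyl exchange alone could not show.

On these data alone, whether an amine on this carbon, or a longer chain in place of butyl, would restore a lower number stays open. As far as these compounds go, how far past its limit compound 4 lies also stays open.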